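The source may hold more compounds than are shown below. What is called first, only, known or untested is meant among the compounds shown, and "the series" means these compounds.

Of the compounds shown here, three that share one core have been tested in a functional assay on L1210 cells (Mus musculus) for inhibition; a higher number here means a weaker inhibitor, a lower number a stronger inhibitor. Compound 1 `CN(Cc1cnc2nc(N)nc(N)c2n1)c1ccc(C(=O)NC(CCC(=O)NN)C(=O)O)cc1` gives 0.02 uM, compound 2 `CCCCNC(=O)CCC(NC(=O)c1ccc(N(C)Cc2cnc3nc(N)nc(N)c3n2)cc1)C(=O)O` gives 0.09 uM, and compound 3 `CN(Cc1cnc2nc(N)nc(N)c2n1)c1ccc(C(=O)NC(CCC(=O)O)C(=O)OC(C)(C)C)cc1` gives 5.2 uM. Compound 2 therefore sits in the middle of the three, much closer to compound 1 than to compound 3.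

Compound 4 `CN(Cc1cnc2nc(N)nc(N)c2n1)c1ccc(C(=O)NC(CCC(=O)OC(C)(C)C)C(=O)O)cc1` has not yet been measured. The structural change leading to it is tert-butoxy in place of butylamino on a carbonyl carbon, which turns butylcarbamoyl into tert-butoxycarbonyl.

Within the data shown here, only one measured step bears directly on this. Placing butyl in place of amino on an amide-type nitrogen, on that same carbonyl carbon, gave a 4.5-fold higher number from compound 1 to compound 2 (0.65 log units; beyond the scatter), a modest step. Compound 3 also carries tert-butoxy, but on a different carbonyl carbon, so its 5.2 uM is a weak guide here. No firm direction can be drawn from this evidence, so no change beyond the scatter is the best expectation in this assay.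

The expected outcome is a 1.1-fold higher number from compound 2 to compound 4 (0.05 log units; within the scatter). Compound 4 is estimated at 0.1 uM, with an expected range from 0.03 uM to 0.35 uM.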

Compound 4, concentration for 50% inhibition: 0.02 uM
Beside the measured number, compound 4's estimate is 5.0-fold (0.70 log units) above it; the whole stated range lies above it.
By their numbers in this assay, from the lowest: compounds 1 and 4 (each within the scatter of the next); then compound 2; then compound 3.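

In this assay, putting tert-butoxy in place of butylamino on this carbonyl carbon gives a 4.5-fold lower number from compound 2 to compound 4 (0.65 log units; beyond the scatter), so the two groups are far from interchangeable here even though they have the same number of heavy atoms. Tert-butoxy also gives no change at the digits printed from compound 1 to compound 4 (within the scatter), which means that the butylamino of compound 2 is the group that stands apart among these three at this carbon. Nothing measured here explains the difference between these groups.

Going by these compounds, what remains open is whether the step follows the swap of nitrogen for oxygen or the change from a straight to a branched chain. Butoxy with a straight chain, or tert-butylamino, on this carbonyl carbon would separate those two changes.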